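Swapping the aryl group for a furan ring

The compounds below may be only part of what the source reports. "The series", "measured", "known", "first", "only" and "open" are said of these compounds alone.

Among the measured compounds shown here, the two compounds measured so far share one core and differ only in the aromatic group on a saturated chain carbon bound to an amide-type nitrogen and a saturated chain carbon. Compound 1 `Cc1nc(N)sc1CCCN/C(N)=N/C(=O)NC(C)c1ccccc1F` carries a 2-fluorophenyl there; in a functional assay on Right cardiac atrium for agonist activity at histamine H2 receptor (Cavia porcellus), with a stated time of 30 min, in the presence of a further agent that is not named here (on this read-out lower numbers stand for an effect already at smaller amounts and higher numbers for an effect only at larger amounts of compound), compound 1 gives 12.3 nM. Compound 2 `Cc1nc(N)sc1CCCN/C(N)=N/C(=O)NC(C)c1ccc(Cl)cc1` carries a 4-chlorophenyl, and in this assay compound 2 gives 24.6 nM. The step of a 2.0-fold higher number from compound 1 to compound 2 (0.30 log units; within the scatter) is the only one measured. For the measured compounds named here, compound 2 thus has the highest of the two numbers, yet its only neighbour, compound 1, lies within the scatter of it.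

Compound 3 `Cc1nc(N)sc1CCCN/C(N)=N/C(=O)NC(C)c1ccco1` is not yet measured. It differs from compound 2 as follows: furan-2-yl in place of 4-chlorophenyl on a saturated chain carbon bound to an amide-type nitrogen and a saturated chain carbon. Going by the values given here, the one measured step bears on this change only loosely, since it also exchanged one six-membered aromatic ring for another and stayed within the scatter. Among the compounds with values here, no step with a five-membered ring at this place has been seen, so a wider range is needed. Compound 3 is expected to give about 25 nM, between 8 nM and 80 nM, which is the estimated step of a 1.0-fold higher number from compound 2 to compound 3 (0.01 log units; within the scatter).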

Compound 3, half-maximal effective concentration: 9.77 nM
Compound 3: the middle estimate sits 2.6-fold (0.41 log units) above what was measured; low and high end bracket the measured number.
By their numbers in this assay, from the lowest: compounds 3, 1 and 2 (each within the scatter of the next, the first and the last beyond it).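

Among the compounds shown here, the furan-2-yl group is accepted at this place on a saturated chain carbon bound to an amide-type nitrogen and a saturated chain carbon, and a five-membered aromatic ring with one hetero atom can stand in for a six-membered ring of carbon only: in this assay the exchange gives a 2.5-fold lower number from compound 2 to compound 3 (0.40 log units; beyond the scatter) and so is the first step at this place to pass beyond the scatter. That difference holds only against the 4-chlorophenyl, since the exchange for the 2-fluorophenyl gives a 1.3-fold lower number from compound 1 to compound 3 (0.10 log units; within the scatter) and leaves compound 1 and compound 3 indistinguishable, so ring size alone does not sort these three compounds. No accompanying measurement speaks to what lies behind either step.

The three compounds leave open whether the ring oxygen of the furan-2-yl matters at all, a question that a thiophen-2-yl or an unsubstituted phenyl at the same place would address. Also open, going by these compounds, is how this place responds to a group without an aromatic ring, such as a cyclohexyl or a longer chain ending in an amine.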